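A Small Ester Swap on an Inactive Compound

The compounds below may be only part of what the source reports. "The series", "measured", "known", "first", "only" and "open" are said of these compounds alone.

Compound 1 (`CCCCCCCCCCCC(=O)OC[C@H]1O[C@@H](O[C@@H]2OC=C(C(=O)OC)[C@H]3C[C@H](OC(C)=O)[C@H](C)[C@@H]23)[C@H](OC(C)=O)[C@@H](OC(C)=O)[C@@H]1OC(C)=O`) and compound 2 (`C=CC(=O)OC[C@H]1O[C@@H](O[C@@H]2OC=C(C(=O)OC)[C@H]3C[C@H](OC(C)=O)[C@H](C)[C@@H]23)[C@H](OC(C)=O)[C@@H](OC(C)=O)[C@@H]1OC(C)=O`) share a core and differ in one ester group. In a functional assay on WRL68 cells (Homo sapiens) for cytotoxicity, read by MTT assay, with a stated time of 4 h (on this read-out higher numbers stand for weaker inhibition and lower numbers for stronger inhibition), compound 1 gives 0.85 ug/mL as its reading. Compound 2 has no single number: its result is "not active" (no number reported) in the report, so the gap between the two cannot be sized. Compound 3 (`COC(=O)C1=CO[C@@H](O[C@@H]2O[C@H](COC(=O)C=C(C)C)[C@@H](OC(C)=O)[C@H](OC(C)=O)[C@H]2OC(C)=O)[C@@H]2[C@@H](C)[C@@H](OC(C)=O)C[C@H]12`) has not been measured yet. The structural change 2-methylprop-1-en-1-yl in place of vinyl on a carbonyl carbon puts 2-methylprop-1-en-1-yl in place of vinyl on a carbonyl carbon. In this assay a modest step toward stronger inhibition is expected, and another result without a number would be no surprise. This expectation leans on compound 2 and its "not active" (no number reported) result, since the swap is a small one. The estimate for compound 3 is an expected half-maximal inhibitory concentration of 10 ug/mL with a likely range from 1.5 ug/mL to 50 ug/mL around it.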

Compound 3, half-maximal inhibitory concentration: 1.2 ug/mL
Compound 3: middle estimate off by 8.3-fold (0.92 log units), on the high side; measured number outside the range, below it.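

In this assay the result is a 1.4-fold higher number from compound 1 to compound 3 (0.15 log units; within the scatter), so on this carbonyl carbon a 2-methylprop-1-en-1-yl group and the much longer undecyl chain cannot be told apart. A long chain is therefore not required for a measurable reading here, while compound 2, which carries vinyl at the same place, is reported as "not active" (no number reported) and so the step from it to compound 3 cannot be sized. Nothing available explains why vinyl stands apart from the other two groups.

The compounds shown leave open whether a saturated chain of middling length, such as butyl, would also give a number in this assay. They also leave open what a phenyl ring or an amine at this place would do.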